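The source may report more compounds than this note shows. Statements on the series, on what has been measured and on what is new or still open speak of the compounds shown alone.

Measured in a functional assay on K562 cells (Homo sapiens) for inhibition, read by trypan blue exclusion, with a stated time of 72 h (a higher number here means a weaker inhibitor, a lower number a stronger inhibitor), so far:
compound 1 `Cn1c(=O)c(S(=O)(=O)c2ccc(F)cc2)cc2cnc(Nc3ccc4occc4c3)nc21` gives 5000 nM
compound 2 `Cn1c(=O)c(C(=O)Nc2ccc(F)cc2F)cc2cnc(Nc3ccc4[nH]ccc4c3)nc21` gives 5000 nM
compound 3 `Cn1c(=O)c(C(=O)Nc2ccc(F)cc2)cc2cnc(Nc3ccc4[nH]ccc4c3)nc21` gives 5000 nM

Compound 3 stands level with compounds 1 and 2, and all three show the same value at the digits given. The next compound, compound 4 `Cn1c(=O)c(S(=O)(=O)c2ccc(F)cc2)cc2cnc(Nc3ccc4[nH]ccc4c3)nc21`, keeps the core of compound 3 and exchanges one substituent: (4-fluorophenyl)sulfonyl in place of (4-fluorophenyl)carbamoyl on an aromatic carbon.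

Only one measured step connects two of these compounds directly, and it concerns a different place: hydrogen in place of fluoro gave no change at the digits printed from compound 2 to compound 3 (within the scatter) (within the scatter). Within the data shown here, no measured step makes the carbamoyl-to-sulfonyl exchange with everything else held constant. The nearest indirect evidence is compound 1, which already carries the (4-fluorophenyl)sulfonyl group and gives 5000 nM (level with compound 3, though its core differs). With nothing pointing either way, no shift beyond the scatter is expected in this assay and no direction is favoured. The estimated outcome is no change at the digits printed from compound 3 to compound 4 (within the scatter) (an expectation only). Compound 4 is expected at 5000 nM with an estimated range from 2000 nM to 10000 nM (not yet measured).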

Compound 4, half-maximal inhibitory concentration: 200 nM
For compound 4 the middle estimate is 25-fold (1.40 log units) above the measured one; the whole stated range lies above it.
By their numbers in this assay, from the lowest: compound 4; then compounds 1, 2 and 3 (each within the scatter of the next).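

In this assay the position on the aromatic carbon, silent until now, turns out to respond strongly: (4-fluorophenyl)sulfonyl in place of (4-fluorophenyl)carbamoyl gives a 25-fold lower number from compound 3 to compound 4 (1.40 log units; beyond the scatter) and the same group in place of (2,4-difluorophenyl)carbamoyl gives a 25-fold lower number from compound 2 to compound 4 (1.40 log units; beyond the scatter) on the same core. The sulfonyl group does not produce this alone, since compound 1 carries it and gives 5000 nM with 1-benzofuran-5-yl on the nitrogen, and 1H-indol-5-yl in that place gives a 25-fold lower number from compound 1 to compound 4 (1.40 log units; beyond the scatter) at the other end of the change. Among these four compounds the low number therefore appears only where (4-fluorophenyl)sulfonyl and 1H-indol-5-yl occur together, while compounds 1, 2 and 3 each carry just one of the two.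

Nothing available accounts for the size of these steps and so the reason for the drop remains unknown. As far as these compounds go, it also stays open whether the aromatic ring on the sulfonyl group is needed at all, which a methyl or a morpholine on the sulfur would address, and whether a plain phenyl would serve in place of the 4-fluorophenyl ring.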